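Swapping a sulfonamide group on compound 2

The source may hold more compounds than are shown below. What is called first, only, known or untested is meant among the compounds shown, and "the series" means these compounds.

Measured so far in a functional assay on OVCAR-3 cells (Homo sapiens) for activation, with a stated time of 24 h; a higher number here means that more compound is needed for the effect, a lower number that less compound is needed:
compound 1 `CC(C)(C)NS(=O)(=O)c1cccc(NC(=O)c2ccc(NS(=O)(=O)C3(C)CC3)cc2N2CCC3(CC2)CC3)c1`: 11 nM
compound 2 `CC(C)(C)NS(=O)(=O)c1cccc(NC(=O)c2cccnc2N2CCC3(CC2)CC3)c1`: 1030 nM

For the measured compounds named here, only two compounds have been measured so far, and a lower number means that less compound is needed for the effect. Compound 2 has the higher number of the two at 1030 nM, and its gap to compound 1 at 11 nM lies well beyond the usual scatter. These two compounds differ in more than one place, so their gap says nothing about any single group.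

The next compound is compound 3 `O=C(Nc1cccc(S(=O)(=O)N2CCCC2)c1)c1cccnc1N1CCC2(CC1)CC2`, which differs from compound 2 in one place: pyrrolidin-1-yl in place of (tert-butyl)amino on a sulfonyl sulfur. In words, pyrrolidin-1-yl stands in place of (tert-butyl)amino on a sulfonyl sulfur. Going by the values given here, no measured pair shows this change, so the data give no direct guide to its size in this assay.

The expected change is a 1.9-fold higher number from compound 2 to compound 3 (0.29 log units; within the scatter), a moderate move towards a higher number, though this is only an estimate. For compound 3 the estimated value is 2000 nM, with an expected range from 500 nM to 8000 nM.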

Compound 3, half-maximal effective concentration: 5460 nM
For compound 3 the middle estimate is 2.7-fold (0.44 log units) below the measured one; the measured number falls inside the stated range.
By their numbers in this assay, from the lowest: compound 1; then compound 2; then compound 3.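

In this assay, for the compounds shown here, putting pyrrolidin-1-yl in place of (tert-butyl)amino on a sulfonyl sulfur gives a 5.3-fold higher number from compound 2 to compound 3 (0.72 log units; beyond the scatter) and so provides the first comparison in this set that can be tied to a single place. The result shows that the group on the sulfonyl sulfur matters in this assay, even though the two groups have the same count of heavy atoms, so a swap that leaves that count unchanged can still shift the number beyond the usual scatter. The groups differ in that pyrrolidin-1-yl closes a ring and has no hydrogen-bond donor, while (tert-butyl)amino is open and has one, but no measurement here shows which of these differences, if either, accounts for the step.

The compounds shown leave open whether a group that keeps the nitrogen hydrogen without the bulky branched carbon, such as methylamino, would stay closer to compound 2, and whether a six-membered ring such as piperidin-1-yl would behave like pyrrolidin-1-yl. As far as these compounds go, it also remains open whether the same swap would have a similar effect on the core of compound 1, which has a much lower number in this assay.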